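Swapping the Acid-Bearing Ring in a Glutamate Receptor Modulator

The compounds below may be only part of what the source reports. "The series", "measured", "known", "first", "only" and "open" are said of these compounds alone.

Of the compounds shown here, two have been measured so far. Compound 1 `Cc1c(OCCCCOc2ccc(C(=O)O)cc2Cl)ccc(C(=O)CC2CCCC2)c1O` and compound 2 `Cc1c(OCCCCOc2ccc(C(=O)CC(C)(C)C)c(O)c2C)cccc1C(=O)O` share a core in which a saturated chain links two aromatic rings through oxygen atoms. In an assay on HEK293 cells for positive allosteric modulation of metabotropic glutamate receptor 2 (Rattus norvegicus), read by thallium flux, with a stated time of 2.5 min (a lower number here means a smaller maximal response, a higher number a larger maximal response), compound 1 gives 82.2%, and compound 2 gives 95.8%. Compound 1 thus stands lowest of the two numbers, and the gap to compound 2 lies beyond the usual scatter, so compound 2 reaches the larger maximal response.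

Compound 3 `Cc1cc(OCCCCOc2ccc(C(=O)CC3CCCC3)c(O)c2C)ccc1C(=O)O` has not been measured yet. It differs from compound 1 in one place: 4-carboxy-3-methylphenyl in place of 4-carboxy-2-chlorophenyl on an oxygen on a saturated carbon. Within the data shown here, no measured pair bridges this exact change, so there is no step of the same kind to lean on, and the expectation rests only on the two numbers above. Compound 2 shows that a methyl group and a carboxylic acid on one aromatic ring is compatible with a high maximal response, but the arrangement there is not the same as in compound 3. The expected step is a number 5.8 percentage points higher from compound 1 to compound 3 (within the scatter), a small rise that may well stay within the scatter. Compound 3 is therefore estimated at 88%, with a range from 70% to 105%.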

Compound 3, largest response reached (reported as percent of maximum), in percent of the reference or control that the assay uses: 83.6%
Compound 3: the middle estimate sits 4.4 percentage points above what was measured, within the range that was stated.
By their numbers in this assay, from the lowest: compounds 1 and 3 (each within the scatter of the next); then compound 2.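

Among these compounds, this is the first measured pair that differs in one place, so it gives the first direct reading of this change. In this assay putting 4-carboxy-3-methylphenyl in place of 4-carboxy-2-chlorophenyl, on an oxygen on a saturated carbon, gives a number 1.4 percentage points higher from compound 1 to compound 3 (within the scatter) and so leaves the two compounds indistinguishable in maximal response. For this pair, then, the chlorine can give way to a methyl group on the acid-bearing ring, with the carboxylic acid and the rest of the molecule kept, without a response difference that stands out from the usual scatter, and nothing available here gives a reason for that.

The swap alters the kind of group and also the number it carries in the ring's name, so this single pair cannot separate those two parts of the change. Also open, on these data alone, is how the response would read with a plain 4-carboxyphenyl at this place, or with a fluorine atom or a methoxy group on that ring in place of the chlorine or the methyl group.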